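The source may report more compounds than this note shows. Statements on the series, on what has been measured and on what is new or still open speak of the compounds shown alone.

Within the data shown here, compound 1 `Cc1nc(SCC(=O)Nc2nc(-c3ccc(Cl)cc3)cs2)n(Nc2ccccc2)c1C` is the one compound of this pair that gives a number in a functional assay on UACC-62 cells (Homo sapiens) for antiproliferative activity, read by sulforhodamine B assay, with a stated time of 48 h; on this read-out higher numbers stand for lower toxicity in this test and lower numbers for higher toxicity in this test: compound 1 gives 50300 nM. Among the measured compounds shown here, the only other value on this read-out is a limit: compound 2 `Cc1ccc(Nn2c(SCC(=O)Nc3nc(-c4ccccc4)cs3)nc(C)c2C)cc1` gives > 100000 nM in this assay, which is a limit of the assay and not a number, as the limit of > 100000 nM in this assay, at which 1 of the 2 values shown sits, records. Compound 3 `COc1ccc(Nn2c(SCC(=O)Nc3nc(-c4ccc(Cl)cc4)cs3)nc(C)c2C)cc1` has not yet been measured in this assay. It differs from compound 1 by methoxy in place of hydrogen on an aromatic carbon. For the measured compounds named here, no measured pair that differs in that single place is available, so the size of the step has to be guessed. Going by the values given here, the anilino phenyl of compound 1 bears no substituent, and the closest comparison, compound 2, carries a different group there together with a second change, so it shows only that its value sits at the limit. Given that compound 1 already lies high in this assay, compound 3 is expected to stay weak, with an estimated step from a 1.4-fold higher number from compound 1 to compound 3 (0.14 log units; within the scatter) and an expected value of 70000 nM, within 25000 nM to 200000 nM.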

Compound 3, concentration lethal to 50% of the cells: > 100000 nM
Compound 3: only a limit was reported (the forecaster's own chance of this, stated with the estimate: 45%); middle value at least 1.4-fold (0.15 log units) away from the limit.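

Methoxy in place of hydrogen, para to a large group, gives the first comparison at this position that differs in one place only (an at least 1.9-fold higher number from compound 1 to compound 3 (0.29 log units; that floor lies within the scatter)). In this assay compound 3 gives > 100000 nM, which is a limit of the assay and not a number. The pair therefore gives no sign that 4-methoxyphenyl in place of phenyl brings higher toxicity in this test, but the true size of the step cannot be read, as the reading stops at the edge of the test: the limit of > 100000 nM in this assay, at which 2 of the 3 values shown sit.

Going by these compounds, whether an amine, a carboxylic acid or a halogen such as fluorine at this place would give a number lower than that of compound 1 remains open. Among these compounds, compound 2 differs from compound 1 and compound 3 in more than one place, so it adds no step here.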